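A few compounds are considered here, and "the series" means these few. Any claim that something is new, unique, unknown or untested is made for them only; others in the source may bear on it.

Measured so far in a functional assay on HeLa cells (Homo sapiens) for cytotoxicity; a higher number here means a weaker inhibitor, a lower number a stronger inhibitor

compound 1 `C/C=C/C(=O)OC1=CC(=O)c2ccccc2C1=O` gives 37900 nM
compound 2 `O=C(OC1=CC(=O)c2ccccc2C1=O)c1ccccc1` gives 55000 nM
compound 3 `COc1ccc2c(c1)C(=O)C=CC2=O` gives 22700 nM

Compound 1 lies within the scatter of both compound 2 and compound 3. Going to compound 4 `CCOC1=CC(=O)c2ccccc2C1=O` is the change ethyl in place of (prop-1-en-1-yl)carbonyl on an oxygen on an unsaturated carbon and reads ((prop-1-en-1-yl)carbonyl)oxy to ethoxy when cut one bond further out. Among the measured compounds shown here, the one measured step bearing on this is a 1.5-fold higher number from compound 1 to compound 2 (0.16 log units; within the scatter) and it swaps only the group on the carbonyl carbon, so the evidence is indirect. For the measured compounds named here, no measured pair removes that carbonyl. In this assay no step beyond the scatter is expected, and a 1.3-fold lower number from compound 1 to compound 4 (0.10 log units; within the scatter) is the estimated step, with no firm direction. For compound 4 an estimate of 30000 nM is expected, within an estimated range from 12000 nM to 70000 nM as a working guess.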

Compound 4, half-maximal inhibitory concentration: 23800 nM
The estimate for compound 4 lay 1.3-fold (0.10 log units) above the measured number; the range from low to high includes it.
By their numbers in this assay, from the lowest: compounds 3, 4, 1 and 2 (each within the scatter of the next, the first and the last beyond it).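

The earlier step changed only the group on the carbonyl carbon, whereas here the carbonyl itself goes: in this assay, ethyl replacing (prop-1-en-1-yl)carbonyl gives a 1.6-fold lower number from compound 1 to compound 4 (0.20 log units; within the scatter) and stays within the scatter. On this oxygen, then, neither the carbonyl nor the larger group with its two double bonds is needed to keep the number in this range. Nothing available explains this result.

Still open, on these data alone, is whether an amine, a carboxylic acid or a longer chain on this oxygen would give a step beyond the scatter. As far as these compounds go, a free hydroxyl on the same oxygen is an equally open case.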